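The source may hold more compounds than are shown below. What is called first, only, known or untested is meant among the compounds shown, and "the series" means these compounds.

Of the compounds shown here, two of a shared core have been measured. Compound 1, `CS(=O)(=O)NC(=O)c1ccc(C2CC2c2ccc(OCc3c(-c4c(Cl)cccc4Cl)noc3C3CC3)cc2Cl)cc1`, reaches 88% in an assay on HEK293 cells for agonist activity at Bile acid receptor (Homo sapiens); a lower number here means a smaller maximal response, a higher number a larger maximal response. Compound 2, `O=C(O)c1cccc([C@H]2C[C@@H]2c2ccc(OCc3c(-c4c(Cl)cccc4Cl)noc3C3CC3)cc2Cl)c1`, carries a carboxylic acid in place of the acyl sulfonamide of compound 1 and in this assay compound 2 gives 88%. Compound 2 therefore stands level with compound 1 at the digits shown; the two values lie within the scatter of the method, so nothing of order can be said between them.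

Compound 3, `O=C(O)c1cncc(C2CC2c2ccc(OCc3c(-c4c(Cl)cccc4Cl)noc3C3CC3)cc2Cl)c1`, has not yet been measured. It differs from compound 2 in one place: 2-(5-carboxypyridin-3-yl)cyclopropyl in place of 2-(3-carboxyphenyl)cyclopropyl on an aromatic carbon, the change sitting on an aromatic carbon of a six-membered aromatic ring of carbon only, ortho to a chloro group and para to a large group. Within the data shown here, no step between measured compounds is available for this kind of change, so the expectation rests on the near-equal values of compound 1 and compound 2 alone. The step expected in this assay is small, a number 3 percentage points lower from compound 2 to compound 3 (within the scatter), not clearly beyond the scatter in either direction. Compound 3 is accordingly estimated at 85% in this assay, within a range of 65% to 100%.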

Compound 3, largest response reached (reported as efficacy), in percent of the reference or control that the assay uses: 73%
Estimate against measurement, compound 3: 12 percentage points above, and the stated range covers the measured number.
By their numbers in this assay, from the lowest: compound 3; then compounds 1 and 2 (each within the scatter of the next).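

In this assay, placing 2-(5-carboxypyridin-3-yl)cyclopropyl where 2-(3-carboxyphenyl)cyclopropyl stood gives a number 15 percentage points lower from compound 2 to compound 3 (beyond the scatter), so the group on this aromatic carbon, ortho to a chloro group and para to a large group, is not indifferent to the make-up of the ring that carries the carboxylic acid. That is something the level values of the two earlier compounds could not show. The step covers more than one difference, since the entering group has a six-membered aromatic ring with 1 hetero atom in place of one of carbon only and lacks the 2 defined stereocentres of the leaving group, and nothing available explains the lower maximal response.

The compounds shown leave open whether the ring nitrogen or the undefined stereocentres account for the step, which a single stereoisomer of compound 3 would help to separate. They also leave open whether a fluoro or methoxy group on the carbon-only ring would lower the response in the same way, and whether the acyl sulfonamide of compound 1 would fare differently on the nitrogen-containing ring.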